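Moving a Methyl Group on a Sulfonamide Aryl Ring

The compounds below may be only part of what the source reports. "The series", "measured", "known", "first", "only" and "open" are said of these compounds alone.

Of the compounds shown here, three sharing one core have been tested in a functional assay on M21 cells (Homo sapiens) for antiproliferative activity, read by sulforhodamine B assay, with a stated time of 48 h; a higher number here means a weaker inhibitor, a lower number a stronger inhibitor. Compound 1 `O=C1NCCN1c1ccc(S(=O)(=O)Nc2ccc3[nH]ccc3c2)cc1` gives 87 nM. Compound 2 `CCCCc1ccc(NS(=O)(=O)c2ccc(N3CCNC3=O)cc2)cc1` gives 450 nM. Compound 3 `Cc1ccc(NS(=O)(=O)c2ccc(N3CCNC3=O)cc2)cc1C` gives 94 nM, which places it second highest of the three numbers; the number of compound 1 lies within the scatter of it, while the number of compound 2 lies beyond the scatter and above it. So compound 3 and compound 1 cannot be told apart on these data, and only compound 2 stands clearly as the weaker inhibitor of the three.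

Compound 4 `Cc1cccc(NS(=O)(=O)c2ccc(N3CCNC3=O)cc2)c1C` has not yet been measured in this assay . It differs from compound 3 in one place: 2,3-dimethylphenyl in place of 3,4-dimethylphenyl on a sulfonamide nitrogen. For the measured compounds named here, no measured pair in this set shows what such a rearrangement does, so the expectation rests on the fact that the two structures contain the same atoms and that compound 3 gives 94 nM. The step expected is small, a 1.6-fold higher number from compound 3 to compound 4 (0.20 log units; within the scatter), leaning toward a slightly weaker inhibitor but not beyond the scatter. Compound 4 is therefore expected to give about 150 nM, with a likely range from 50 nM to 500 nM.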

Compound 4, half-maximal inhibitory concentration: 110 nM
Estimate against measurement, compound 4: 1.4-fold (0.13 log units) above, within the range that was stated.
By their numbers in this assay, from the lowest: compounds 1, 3 and 4 (each within the scatter of the next); then compound 2.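

For the compounds shown here, compound 3 and compound 4 form the first pair in this set that differs in only one place, so they give the first direct look at the aryl group on the sulfonamide nitrogen. In this assay, placing 2,3-dimethylphenyl where 3,4-dimethylphenyl stood gives a 1.2-fold higher number from compound 3 to compound 4 (0.07 log units; within the scatter), so the two compounds cannot be told apart and this rearrangement of the same atoms has no effect that these data can detect. No measurement offered here explains this outcome, so the pair records what happened but not why.

Going by these compounds alone, the pair covers only two dimethylphenyl groups, so it remains open whether the insensitivity extends to other groups on this ring, such as a methoxy group, a chlorine atom, an amine or a carboxylic acid. All of these numbers also come from a single cell line read at a single time, so whether compound 3 and compound 4 would stay equally close in other cells is also unknown.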